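The compounds below may be only part of what the source reports. "The series", "measured", "known", "first", "only" and "open" are said of these compounds alone.

Of the compounds shown here, three built on a shared core have so far been measured in an ADME assay on HeLa cells (Homo sapiens) for cytotoxicity, read by MTT assay; on this read-out lower numbers stand for stronger inhibition and higher numbers for weaker inhibition. Compound 1 `COC(=O)[C@@H]1CCCN1C(=O)CCC(=O)Oc1ccc(C[C@H]2C(=O)OC[C@@H]2Cc2ccc(OC)c(OC)c2)cc1OC` gives 145000 nM, compound 2 `COc1ccc(C[C@H]2COC(=O)[C@@H]2Cc2ccc(OCc3cn(Cc4ccc(Cl)cc4)nn3)c(OC)c2)cc1OC` gives 242000 nM, and compound 3 `CCN(CC)C(=O)COc1ccc(C[C@H]2C(=O)OC[C@@H]2Cc2ccc(OC)c(OC)c2)cc1OC` gives 188000 nM. Compound 3 thus has its number placed among the other two, but the gap to compound 2 is within the usual scatter and the gap to compound 1 is likewise within the scatter, so the three cannot be told apart on this read-out.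

Compound 4 `COc1ccc(C[C@H]2COC(=O)[C@@H]2Cc2ccc(OCc3cn(-c4ccccc4)nn3)c(OC)c2)cc1OC` has not yet been measured in this assay. It differs from compound 3 at a single place: 1-phenyl-1H-1,2,3-triazol-4-yl in place of diethylcarbamoyl on a saturated chain carbon bound to an oxygen on an aromatic ring. Compound 2 already carries a 1,2,3-triazol-4-yl group of its own on a saturated chain carbon bound to an oxygen on an aromatic ring, and its number lies within the scatter of compound 3. Going by the values given here, no step between measured compounds covers this particular change, so the expectation rests on that resemblance. Compound 4 is therefore expected to show a step of a 1.2-fold higher number from compound 3 to compound 4 (0.09 log units; within the scatter), a move not expected to reach beyond the scatter, leaning if anything toward the weaker side. Compound 4 is estimated at 230000 nM, with a range from 120000 nM to 450000 nM.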

Compound 4, half-maximal inhibitory concentration: 124000 nM
Compound 4: the middle estimate sits 1.9-fold (0.27 log units) above what was measured, and the stated range covers the measured number.
By their numbers in this assay, from the lowest: compounds 4, 1, 3 and 2 (each within the scatter of the next).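

In this assay, putting 1-phenyl-1H-1,2,3-triazol-4-yl in place of diethylcarbamoyl on a saturated chain carbon bound to an oxygen on an aromatic ring gives a 1.5-fold lower number from compound 3 to compound 4 (0.18 log units; within the scatter) and so does not separate the two compounds on this read-out. Going by these compounds alone, the result also provides the first comparison of two compounds that both carry the triazole: phenyl in place of 4-chlorobenzyl on an aromatic nitrogen gives a 2.0-fold lower number from compound 2 to compound 4 (0.29 log units; within the scatter) and likewise leaves the two compounds unseparated. Thus, neither the exchange at the saturated chain carbon nor the exchange on the aromatic nitrogen produces a difference that can be told from the scatter, and no information is available on why these compounds read alike.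

On these data alone, it remains open whether a primary amine or a carboxylic acid in place of these groups on the saturated chain carbon would give a step beyond the scatter. As far as these compounds go, it is equally open whether a methyl group or a longer alkyl chain on the aromatic nitrogen of the triazole would do so.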